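Moving the methyl around the pyridine ring of compound 3

The source may report more compounds than this note shows. Statements on the series, on what has been measured and on what is new or still open speak of the compounds shown alone.

Of the compounds shown here, three sharing one core have been measured in a physicochemical assay for lipophilicity, read by LC-MS, in phosphate buffer, measured as octanol-water partition, with a stated time of 30 min, at pH 7.4, tested at 200 mM; a lower number here means a more polar compound, a higher number a more lipophilic compound. Compound 1 `Cn1c(COc2cccc(C(=O)O)c2)nc2ccc(Oc3ccc(Cl)cn3)cc21` gives 1.2, compound 2 `Cn1c(COc2cccc(C(=O)O)c2)nc2ccc(Oc3ncccc3Cl)cc21` gives 1.1, and compound 3 `Cc1cccc(Oc2ccc3nc(COc4cccc(C(=O)O)c4)n(C)c3c2)n1` gives 0.8. Compound 3 sits apart from compound 1, since a number 0.40 log units lower from compound 1 to compound 3 (beyond the scatter), while it lies within the scatter of compound 2, as a number 0.30 log units lower from compound 2 to compound 3 (within the scatter) shows. Compound 4 `Cc1ccnc(Oc2ccc3nc(COc4cccc(C(=O)O)c4)n(C)c3c2)c1` has not yet been measured in this assay; it differs from compound 3 only in that (4-methylpyridin-2-yl in place of 6-methylpyridin-2-yl on an oxygen on an aromatic ring). Among the compounds with values here, the closest precedent is the step in which the chlorine changes its position on the same pyridine, where a number 0.10 log units lower from compound 1 to compound 2 (within the scatter). On that basis compound 4 is expected to stay where compound 3 stands, with no change at the digits printed from compound 3 to compound 4 (within the scatter) estimated as the step and no shift beyond the scatter anticipated. The estimate for compound 4 in this assay is therefore 0.8, between 0.5 and 1.1.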

Compound 4, distribution coefficient: 0.8
Beside the measured number, compound 4's estimate shows no gap at the digits printed; measured number inside the range.
By their numbers in this assay, from the lowest: compounds 3, 4, 2 and 1 (each within the scatter of the next, the first and the last beyond it).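

In this assay, 4-methylpyridin-2-yl in place of 6-methylpyridin-2-yl gives no change at the digits printed from compound 3 to compound 4 (within the scatter), so the two methylpyridines on this oxygen cannot be told apart by this measure. Compound 4 also repeats the relation of compound 3 to the two chlorinated compounds, with a number 0.30 log units lower from compound 2 to compound 4 (within the scatter) but a number 0.40 log units lower from compound 1 to compound 4 (beyond the scatter); across these compounds, the 5-chloropyridin-2-yl group of compound 1 alone stands beyond the scatter of both methylpyridines. No measured information is available to explain these numbers. The compounds shown leave open whether a methoxy group, an amine or a nitrile in place of the methyl on this pyridine would stay within the scatter of compound 3. They also leave open whether the same indifference to the place of the methyl would hold with an amide in place of the carboxylic acid.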